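Methoxy for methylamino on the shared core

The source may hold more compounds than are shown below. What is called first, only, known or untested is meant among the compounds shown, and "the series" means these compounds.

Three compounds of this series have numbers in an assay on isolated protein for inhibition of serine/threonine-protein kinase TNNI3K (Homo sapiens); on this read-out lower numbers stand for stronger inhibition and higher numbers for weaker inhibition. Compound 1 `CCNc1cc(Oc2ccc(NC(=O)Nc3cccc(C(F)(F)F)c3)cc2)ncn1` gives 25 nM, compound 2 `O=C(Nc1ccc(Oc2ccncn2)cc1)Nc1cccc(C(F)(F)F)c1` gives 160 nM, and compound 3 `CNc1cc(Oc2ccc(NC(=O)Nc3cccc(C(F)(F)F)c3)cc2)ncn1` gives 40 nM. Removing the ethylamino group reads as a 6.4-fold higher number from compound 1 to compound 2 (0.81 log units; beyond the scatter), while shortening the chain on the nitrogen reads as a 1.6-fold higher number from compound 1 to compound 3 (0.20 log units; within the scatter), and adding methylamino to the bare core reads as a 4.0-fold lower number from compound 2 to compound 3 (0.60 log units; beyond the scatter). Compound 3 thus stands at the second highest of the three numbers, close to compound 1 and well apart from compound 2.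

Compound 4 `COc1cc(Oc2ccc(NC(=O)Nc3cccc(C(F)(F)F)c3)cc2)ncn1` differs from compound 3 by methoxy in place of methylamino on an aromatic carbon. Going by the values given here, no measured pair shows an amino-to-alkoxy exchange at this carbon. The step from compound 2 to compound 3 bears on it, since a group with a donor at this position gave a modestly lower number, and the step from compound 1 to compound 3 shows the chain length there mattering little. Methoxy keeps an acceptor but brings no donor, so a number between those of compound 2 and compound 3 is expected, with the change given as a 2.0-fold higher number from compound 3 to compound 4 (0.30 log units; within the scatter) in this assay. For compound 4 the expected value is 80 nM, ranging from 35 nM to 200 nM.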

Compound 4, half-maximal inhibitory concentration: 4000 nM
The estimate for compound 4 lay 50-fold (1.70 log units) below the measured number, outside the stated range (above it).
By their numbers in this assay, from the lowest: compounds 1 and 3 (each within the scatter of the next); then compound 2; then compound 4.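

Methoxy is not interchangeable with the amino groups on this aromatic carbon: in this assay the exchange for methylamino gives a 100-fold higher number from compound 3 to compound 4 (2.00 log units; beyond the scatter) and the exchange for ethylamino gives a 160-fold higher number from compound 1 to compound 4 (2.20 log units; beyond the scatter) on the shared core. The position is also more than a place where substituents are merely lost or gained, as methoxy in place of hydrogen gives a 25-fold higher number from compound 2 to compound 4 (1.40 log units; beyond the scatter) in the opposite direction to a 4.0-fold lower number from compound 2 to compound 3 (0.60 log units; beyond the scatter), so a group here can take the number well past that of the unsubstituted compound 2 as well as lower it. Methylamino and methoxy match in heavy-atom count and hydrogen-bond acceptor count and differ in nitrogen against oxygen and in hydrogen-bond donor count, but no measurement available here accounts for the size of this step.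

The compounds shown leave open whether dimethylamino, which keeps the nitrogen and carries no hydrogen on it, would read with the two amino compounds or with methoxy. They also leave open whether hydroxy or ethoxy at this carbon would follow methoxy, or whether the high number belongs to methoxy alone.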